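Swapping amino for hydroxy in compound 3

The source may hold more compounds than are shown below. What is called first, only, known or untested is meant among the compounds shown, and "the series" means these compounds.

Measured so far in a physicochemical assay for solubility, at pH 7.4; a higher number here means a more soluble compound, a lower number a less soluble compound:
- Compound 1 `Cc1c2c(n3c1CCCNC[C@H](C)Nc1cc-3ccc1C(N)=O)CC(C)(C)CC2=O` gives > 100 ug/mL (a limit)
- Compound 2 `Cc1c2c(n3c1CCN(C(=O)[C@H](C)N)CC[C@H](C)Nc1cc-3ccc1C(N)=O)CC(C)(C)CC2=O` gives > 100 ug/mL (a limit)
- Compound 3 `Cc1c2c(n3c1CCN(C(=O)[C@@H](N)C(C)C)C[C@@H](C)[C@H](C)Nc1cc-3ccc1C(N)=O)CC(C)(C)CC2=O` gives > 100 ug/mL (a limit)

A limit is not a number, and compound 3 has no exact reading. Compound 3 sits at the limit of > 100 ug/mL in this assay, at which 3 of the 3 values shown sit, and so cannot be ranked against the other two.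

Compound 4 (`Cc1c2c(n3c1CCN(C(=O)[C@@H](O)C(C)C)C[C@@H](C)[C@H](C)Nc1cc-3ccc1C(N)=O)CC(C)(C)CC2=O`) differs from compound 3 by one small edit: hydroxy in place of amino on a saturated chain carbon bound to a carbonyl carbon and a saturated chain carbon. The atom swapped out and the atom swapped in each count as a single heavy atom, and neither side carries a net charge.

Within the data shown here, no two measured compounds differ in just one place, so no measured step sets the size of this one. A moderate fall in this assay is still expected, though it may prove small, and the assay may again report only a limit. The expected change, an at least 2.0-fold lower number from compound 3 to compound 4 (0.30 log units; that floor lies within the scatter), is a rough estimate that starts from a limit. In this assay compound 4 is expected to read 50 ug/mL with 10 ug/mL to 150 ug/mL as the estimated range.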

Compound 4, solubility: 30 ug/mL
The estimate for compound 4 lay 1.7-fold (0.22 log units) above the measured number; measured number inside the range.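

In this assay, compound 4 gives the only exact reading among the compounds shown, and it shows that this position responds to the change. Hydroxy in place of amino, on a saturated chain carbon bound to a carbonyl carbon and a saturated chain carbon, gives an at least 3.3-fold lower number from compound 3 to compound 4 (0.52 log units; beyond the scatter), even though one heavy atom replaces one heavy atom and the counts of hydrogen-bond donors and acceptors and the net charge stay the same. The full size of this step remains unknown because compound 3 has only a limit and not a number: the limit of > 100 ug/mL in this assay, at which 3 of the 4 values shown sit.

The compounds shown leave open how a methoxy or a dimethylamino group would read at this same place, and so whether the amino group itself matters or any group other than hydroxy would serve as well. They also leave open whether the same swap would have a similar effect with the 1-aminoethyl group of compound 2, whose chain differs from the 1-amino-2-methylpropyl group of compound 3.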